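Replacing 4-fluorophenyl with furan-2-yl in compound 1

The source may hold more compounds than are shown below. What is called first, only, known or untested is meant among the compounds shown, and "the series" means these compounds.

Measured so far in a functional assay on A-431 cells (Homo sapiens) for cytotoxicity; a higher number here means that more compound is needed for the effect, a lower number that less compound is needed

- compound 1 `COC1=C(C)C(=O)/C(=C(O)/C=C/c2ccc(F)cc2)C(=O)C1(C)C` gives 4.1 ug/mL
- compound 2 `CCc1ccc(/C=C/C(O)=C2/C(=O)C(C)=C(OC)C(C)(C)C2=O)cc1` gives 12 ug/mL
- compound 3 `COC1=C(C)C(=O)/C(=C(O)/C=C/c2c(C)cc(C)cc2C)C(=O)C1(C)C` gives 20 ug/mL

Compound 1 has the lowest of these three numbers, so less of it is needed for the effect than of compound 2 or compound 3. The next compound to be tested is compound 4 `COC1=C(C)C(=O)/C(=C(O)/C=C/c2ccco2)C(=O)C1(C)C`, which has furan-2-yl in place of 4-fluorophenyl on a double-bonded chain carbon bound to a double-bonded chain carbon. The count of what changes reads furan-2-yl in place of 4-fluorophenyl on a double-bonded chain carbon bound to a double-bonded chain carbon and shows that a whole ring is exchanged. The closest measured change is a 2.9-fold higher number from compound 1 to compound 2 (0.47 log units; beyond the scatter) for ethyl in place of fluoro on an aromatic carbon. That modest step leaves the ring itself in place, so it is only indirect evidence. For the measured compounds named here, no measured pair exchanges one ring for another. With compound 2 at 12 ug/mL and compound 3 at 20 ug/mL both higher than compound 1, a modest rise in this assay is expected. The estimated change is a 2.2-fold higher number from compound 1 to compound 4 (0.34 log units; beyond the scatter) and remains uncertain. For compound 4 the estimated value is 9 ug/mL with an expected range from 3.5 ug/mL to 25 ug/mL in this wide estimate.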

Compound 4, concentration for half-maximal effect: 14.7 ug/mL
Beside the measured number, compound 4's estimate is 1.6-fold (0.21 log units) below it; low and high end bracket the measured number.
By their numbers in this assay, from the lowest: compound 1; then compounds 2, 4 and 3 (each within the scatter of the next).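

Exchanging the whole ring at this place, rather than only a group on it, gives a 3.6-fold higher number from compound 1 to compound 4 (0.55 log units; beyond the scatter) in this assay and so moves the number up beyond the scatter, much as the smaller change gave a 2.9-fold higher number from compound 1 to compound 2 (0.47 log units; beyond the scatter) did. Set against the 4-ethylphenyl ring, furan-2-yl gives a 1.2-fold higher number from compound 2 to compound 4 (0.09 log units; within the scatter), so these two different rings cannot be told apart here, and among these three compounds only the 4-fluorophenyl ring of compound 1 stands apart. No measurement here offers a reason for the rise.

The compounds shown leave open whether the higher number goes with the smaller ring, with its oxygen, or simply with the loss of the fluoro group. Plain phenyl, thiophen-2-yl or a phenyl ring carrying an amine at this place would help separate these readings.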